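Swapping the triazole substituent: from sulfonamide to methoxyphenyl

The source may report more compounds than this note shows. Statements on the series, on what has been measured and on what is new or still open speak of the compounds shown alone.

Measured so far in a functional assay on MCF7 cells (Homo sapiens) for antiproliferative activity, read by MTT assay, with a stated time of 72 h; a lower number here means a stronger inhibitor, a higher number a weaker inhibitor:
- compound 1 `COc1ccc(-c2cn(C/C=C3\OC(=O)C(OCc4ccccc4)=C3OCc3ccccc3)nn2)cc1`: 39100 nM
- compound 2 `Cc1ccc(S(=O)(=O)NCc2cn(C[C@H](O)[C@H]3OC(=O)C(OCc4ccccc4)=C3OCc3ccccc3)nn2)cc1`: 6400 nM
- compound 3 `O=C1O/C(=C\Cn2cc(-c3cc(F)cc(F)c3)nn2)C(OCc2ccccc2)=C1OCc1ccccc1`: > 100000 nM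

Compound 3 is reported only as a limit of the assay, (the limit of > 100000 nM in this assay, at which 1 of the 3 values shown sits), not as a number. Among the two numbers shown, compound 2 stands lowest, with compound 1 the nearest and far weaker in this assay. Within the data shown here, the only measured step between single-change neighbours, an at least 2.5-fold higher number from compound 1 to compound 3 (0.40 log units; beyond the scatter), concerns the aryl group on the triazole ring and points to weakening when the 4-methoxyphenyl is lost.

Compound 4 `COc1ccc(-c2cn(C[C@H](O)[C@H]3OC(=O)C(OCc4ccccc4)=C3OCc3ccccc3)nn2)cc1` keeps the hydroxyl-bearing linker and core of compound 2 but carries the change (4-methoxyphenyl in place of (((4-methylphenyl)sulfonyl)amino)methyl on an aromatic carbon). Among the measured compounds shown here, no measured step covers exactly this exchange; compound 1 carries the same 4-methoxyphenyl on a different linker and is much weaker than compound 2, so a weakening is expected, and compound 4 is estimated at 15000 nM (range 4000 nM to 60000 nM), a step of a 2.3-fold higher number from compound 2 to compound 4 (0.37 log units; beyond the scatter) expected in this assay.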

Compound 4, half-maximal inhibitory concentration: 99700 nM
Compound 4: the middle estimate sits 6.6-fold (0.82 log units) below what was measured; the measured number lies above the stated range.
By their numbers in this assay, from the lowest: compound 2; then compound 1; then compound 4. At a limit, above all of these: compound 3.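

With the hydroxyl-bearing linker and the core held fixed, the triazole position proves highly sensitive to this exchange in this assay: a 16-fold higher number from compound 2 to compound 4 (1.19 log units; beyond the scatter). Among these compounds, the earlier step compared only two aryl groups on the other linker, whereas this one shows that 4-methoxyphenyl cannot stand in for (((4-methylphenyl)sulfonyl)amino)methyl, the larger group with a sulfonyl unit and a hydrogen-bond donor. No measurement shown explains this loss.

The exchange changes the size of the group, its sulfonyl unit, its donor and the aromatic ring's attachment all at once, so the compounds shown cannot say which of these matters. A plain aminomethyl group, or an amide carrying the same 4-methylphenyl ring, on this linker would begin to separate those parts.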